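Oxadiazole ring substituents on a thiazolidinedione scaffold in rats

The source may report more compounds than this note shows. Statements on the series, on what has been measured and on what is new or still open speak of the compounds shown alone.

Measured so far:
- compound 1, `O=C1NC(=O)/C(=C/c2ccc(OCCSc3nnc(-c4ccccc4)o3)cc2)S1`: 24.1%
- compound 2, `O=C1NC(=O)/C(=C/c2ccc(OCCSc3nnc(Cc4ccccc4)o3)cc2)S1`: 28%

Both compounds share one core and differ only in the group attached to the five-membered ring. In a functional assay on the whole organism (strain Wistar) with Rattus norvegicus as the target, with a stated time of 15 days, at a dose of 30 mg/kg by the oral route (a higher number here means a stronger effect of the compound at the dose given, a lower number a weaker effect), compound 1 gives 24.1%, and compound 2 gives 28%. For the measured compounds named here, the single measured step, a number 3.9 percentage points higher from compound 1 to compound 2 (within the scatter), came from putting benzyl in place of phenyl on an aromatic carbon. On these two numbers compound 2 has the higher value, but the gap to compound 1 lies within the scatter, so the two cannot be told apart.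

Compound 3, `O=C1NC(=O)/C(=C/c2ccc(OCCSc3nnc(-c4cccnc4)o3)cc2)S1`, has not yet been measured. Compared with compound 2 the change is pyridin-3-yl in place of benzyl on an aromatic carbon. Going by the values given here, no measured step shows this particular exchange; the only known step swaps phenyl for benzyl and is within the scatter, which gives no direction to build on. The expectation is therefore a step of a number 3 percentage points lower from compound 2 to compound 3 (within the scatter) in this assay, not beyond the scatter. Compound 3 is estimated at 25%, within the range 12% to 38%.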

Compound 3, a percentage reported as activity, at one dose (the size of the read-out at that dose, not a potency): 60.8%
The estimate for compound 3 lay 35.8 percentage points below the measured number, and the stated range ends below it.
By their numbers in this assay, from the lowest: compounds 1 and 2 (each within the scatter of the next); then compound 3.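

The aromatic carbon of the five-membered ring with 2 nitrogen and 1 oxygen turns out to be a place where the choice of group matters a great deal. In this assay, pyridin-3-yl in place of benzyl gives a number 32.8 percentage points higher from compound 2 to compound 3 (beyond the scatter), and pyridin-3-yl in place of phenyl gives a number 36.7 percentage points higher from compound 1 to compound 3 (beyond the scatter), whereas the earlier exchange between phenyl and benzyl had shown no separable difference. The large gain therefore goes with pyridin-3-yl, a six-membered aromatic ring with a nitrogen and a hydrogen-bond acceptor that benzyl lacks, although nothing measured here explains how this change raises the number.

The compounds shown leave open whether any ring nitrogen would do or only the one in pyridin-3-yl, a question that pyridin-2-yl, pyridin-4-yl or a pyrimidinyl ring could address. As far as these compounds go, it is also open how far the position tolerates different kinds of group, such as an amine, a carboxylic acid or a longer chain on the same carbon.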